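Swapping the phenylpiperazine arm for a furanylmethylsulfanyl group

The compounds below may be only part of what the source reports. "The series", "measured", "known", "first", "only" and "open" are said of these compounds alone.

Three close relatives share one core and have been measured in an assay on CHO cells for antagonist activity at transient receptor potential cation channel subfamily V member 1 (Homo sapiens), read by FLIPR; on this read-out higher numbers stand for weaker inhibition and lower numbers for stronger inhibition. Compound 1 `CC(C(=O)NCc1ccc(C(F)(F)F)cc1N1CCN(c2ccccc2)CC1)c1ccc(NS(C)(=O)=O)c(F)c1` gives 2 nM there. Compound 2 `Cc1ccc(N2CCN(c3cc(C(F)(F)F)ccc3CNC(=O)C(C)c3ccc(NS(C)(=O)=O)c(F)c3)CC2)cc1` gives 0.7 nM, and compound 3 `COc1ccc(N2CCN(c3cc(C(F)(F)F)ccc3CNC(=O)C(C)c3ccc(NS(C)(=O)=O)c(F)c3)CC2)cc1` gives 1.6 nM. Among these three numbers compound 1 has the highest; the step of a 2.9-fold lower number from compound 1 to compound 2 (0.46 log units; beyond the scatter) is modest, while the step of a 1.3-fold lower number from compound 1 to compound 3 (0.10 log units; within the scatter) stays within the scatter, and between the two variants the step of a 2.3-fold higher number from compound 2 to compound 3 (0.36 log units; beyond the scatter) is again modest.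

Compound 4 `CC(C(=O)NCc1ccc(C(F)(F)F)cc1SCc1ccco1)c1ccc(NS(C)(=O)=O)c(F)c1` changes something larger: ((furan-2-yl)methyl)sulfanyl in place of 4-phenylpiperazin-1-yl on an aromatic carbon. Both measured steps only alter a small group on the distant aromatic ring of the 4-phenylpiperazin-1-yl group, which here leaves entirely, so neither step speaks directly to this change. What they do show is that this part of the molecule tolerates small edits with modest effects. With the whole arm replaced, a larger change is expected, most likely toward a weaker inhibition. Compound 4 is therefore estimated at 10 nM, within a range of 2 nM to 60 nM, which would mean an expected step of a 5.0-fold higher number from compound 1 to compound 4 (0.70 log units; beyond the scatter).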

Compound 4, inhibition constant: 3.2 nM
The estimate for compound 4 lay 3.1-fold (0.49 log units) above the measured number, and the stated range covers the measured number.
By their numbers in this assay, from the lowest: compound 2; then compounds 3, 1 and 4 (each within the scatter of the next).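

In this assay, replacing the whole arm gives a 1.6-fold higher number from compound 1 to compound 4 (0.20 log units; within the scatter), so the two numbers cannot be told apart. The earlier compounds shown here only showed that small edits on the far aromatic ring of the arm have modest effects, whereas this result shows that, in this one replacement, neither the piperazine ring nor the phenyl ring is needed to keep a value in the same range at this position. Nothing available explains why this larger change has so little effect.

Because the sulfur link and the furan ring enter together, the compounds shown do not separate what each contributes. On these data alone, whether a simple methylsulfanyl group, a benzylsulfanyl group or an ether oxygen in place of the sulfur would give a similar number remains open.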